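A Bromine Variant of Compound 2 in Lung Cancer Cells

The source may report more compounds than this note shows. Statements on the series, on what has been measured and on what is new or still open speak of the compounds shown alone.

Among the measured compounds shown here, compound 2 `C=CC(=O)Nc1cccc(NC(=O)CSc2nc(Nc3cccc(F)c3)c3ccccc3n2)c1` gives the lowest of the two numbers so far in a functional assay on NCI-H1975 cells (Homo sapiens) for inhibition, read by MTT assay, with a stated time of 72 h (on this read-out higher numbers stand for weaker inhibition and lower numbers for stronger inhibition), at 2030 nM. For the measured compounds named here, its only measured neighbour is compound 1 `C=CC(=O)Nc1cccc(NC(=O)CSc2nc(Nc3ccccc3F)c3ccccc3n2)c1`, which in this assay gives 6580 nM; the step of a 3.2-fold lower number from compound 1 to compound 2 (0.51 log units; beyond the scatter) came with 3-fluorophenyl in place of 2-fluorophenyl on a nitrogen on an aromatic ring. Compound 3 `C=CC(=O)Nc1cccc(NC(=O)CSc2nc(Nc3ccc(Br)cc3)c3ccccc3n2)c1` differs from compound 2 by 4-bromophenyl in place of 3-fluorophenyl on a nitrogen on an aromatic ring. Going by the values given here, the one measured step concerns a shift of the fluorine on that ring, not an exchange of fluorine for bromine, so it bears only loosely on this change; it shows merely that altering the ring on the nitrogen can move the number by a modest amount. Among the compounds with values here, with no closer precedent, the step is expected to stay within the scatter or be modest in either direction, a 1.1-fold higher number from compound 2 to compound 3 (0.03 log units; within the scatter). Compound 3 is therefore estimated at 2200 nM, within 700 nM to 7000 nM.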

Compound 3, half-maximal inhibitory concentration: 6280 nM
Beside the measured number, compound 3's estimate is 2.9-fold (0.46 log units) below it; the measured number falls inside the stated range.
By their numbers in this assay, from the lowest: compound 2; then compounds 3 and 1 (each within the scatter of the next).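

In this assay, 4-bromophenyl in place of 3-fluorophenyl on this nitrogen gives a 3.1-fold higher number from compound 2 to compound 3 (0.49 log units; beyond the scatter), so a change of both the halogen and its place on the ring moves the number, and the two contributions cannot be told apart from this step. Set against the 2-fluorophenyl of compound 1, the 4-bromophenyl gives a 1.0-fold lower number from compound 1 to compound 3 (0.02 log units; within the scatter), which leaves the 3-fluorophenyl of compound 2 as the only one of the three rings whose number stands apart from the others. Nothing available here accounts for these differences.

The compounds shown leave open how a plain phenyl with no halogen would read on this nitrogen. They also leave open whether a chlorine, a methoxy group or an amine on that ring would match compound 2 or compound 3.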